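This account rests on a few compounds, and the source may have more. Where it says the series, first, only, none or still open, it means among the compounds named here.

Measured compounds:

Compound 1 `N#Cc1ccc(/C=N/Nc2nc(N)c3ncn([C@@H]4O[C@H](CO)[C@@H](O)[C@H]4O)c3n2)cc1` — in an assay on CHO-K1 cells for displacement of a labelled ligand from adenosine receptor A1 (Homo sapiens), read by scintillation counting, with a stated time of 60 min (on this read-out higher numbers stand for weaker inhibition and lower numbers for stronger inhibition), compound 1 gives 4.1 nM
Compound 2 `Nc1nc(N/N=C/c2ccc(Br)cn2)nc2c1ncn2[C@@H]1O[C@H](CO)[C@@H](O)[C@H]1O` — in this assay compound 2 gives 4.7 nM
Compound 3 `CCCCC/C=C/C=C/C=N/Nc1nc(N)c2ncn([C@@H]3O[C@H](CO)[C@@H](O)[C@H]3O)c2n1` — in this assay compound 3 gives 2 nM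

Compound 3 holds the lowest number of the three in this assay; its nearest neighbour is compound 1, as a 2.1-fold lower number from compound 1 to compound 3 (0.31 log units; beyond the scatter) shows, and the wider gap is a 2.4-fold lower number from compound 2 to compound 3 (0.37 log units; beyond the scatter). The two aryl hydrazones sit together, with a 1.1-fold higher number from compound 1 to compound 2 (0.06 log units; within the scatter) between them.

Compound 4 `CCOc1cc(/C=N/Nc2nc(N)c3ncn([C@@H]4O[C@H](CO)[C@@H](O)[C@H]4O)c3n2)ccc1O` returns to an aromatic group on the hydrazone carbon: a group of 10 heavy atoms (8 carbon, 2 oxygen; one six-membered aromatic ring of carbon only) in place of a group of 9 heavy atoms (9 carbon; no ring), on a carbon with a double bond to nitrogen.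

Both measured steps that bear on this change, a 2.1-fold lower number from compound 1 to compound 3 (0.31 log units; beyond the scatter) and a 2.4-fold lower number from compound 2 to compound 3 (0.37 log units; beyond the scatter), run from an aromatic ring to the chain and lower the number by a modest amount. Going the other way, from the chain of compound 3 to a ring, the expectation is a modest rise in the number, as a 3.0-fold higher number from compound 3 to compound 4 (0.48 log units; beyond the scatter), back toward the region where compound 1 and compound 2 sit. Among the compounds with values here, the hydroxy and ethoxy substituents of compound 4 have no counterpart among the measured rings, so the range is kept wide.

Compound 4 is therefore estimated at 6 nM in this assay, with a likely span from 2 nM to 20 nM.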

Compound 4, inhibition constant: 6940 nM
Compound 4: middle estimate off by 1200-fold (3.06 log units), on the low side; measured number outside the range, above it.
By their numbers in this assay, from the lowest: compound 3; then compounds 1 and 2 (each within the scatter of the next); then compound 4.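

In this assay, the place on a carbon with a double bond to nitrogen turns out to be far from indifferent: the earlier chain and ring groups differed only slightly, whereas 3-ethoxy-4-hydroxyphenyl in place of the chain gives a 3500-fold higher number from compound 3 to compound 4 (3.54 log units; beyond the scatter). A ring at this place does not by itself go with the rise, as exchanging one ring group for another gives a 1700-fold higher number from compound 1 to compound 4 (3.23 log units; beyond the scatter) and a 1500-fold higher number from compound 2 to compound 4 (3.17 log units; beyond the scatter), so the identity of the ring group weighs far more here than the choice of ring or chain. Nothing available explains the size of this rise.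

The compounds shown leave open whether the rise goes with the hydroxy group, the ethoxy group or the two together, a question that 4-hydroxyphenyl and 3-ethoxyphenyl on the same carbon would separate. They also leave open how a ring bearing a carboxylic acid or an amine would read in this assay, and whether a methoxy group in place of the ethoxy group would change the number.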